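The source may hold more compounds than are shown below. What is called first, only, known or untested is meant among the compounds shown, and "the series" means these compounds.

In a functional assay on FOCUS cells (Homo sapiens) for cytotoxicity, read by sulforhodamine B assay, with a stated time of 72 h (a higher number here means a weaker inhibitor, a lower number a stronger inhibitor), compound 1 `OC[C@H]1O[C@@H](n2cnc3c(N4CCN(c5ccccc5)CC4)ncnc32)[C@H](O)[C@@H]1O` gives > 100000 nM, which is a limit and not a number. Within the data shown here, compound 2 `OC[C@H]1O[C@@H](n2cnc3c(N4CCN(c5ccc(C(F)(F)F)cc5)CC4)ncnc32)[C@H](O)[C@@H]1O` gives 5200 nM, the only true number so far. Compound 3 `OC[C@H]1O[C@@H](n2cnc3c(N4CCN(c5ccc(Cl)c(Cl)c5)CC4)ncnc32)[C@H](O)[C@@H]1O` has 3,4-dichlorophenyl in place of 4-(trifluoromethyl)phenyl on an amine nitrogen in a ring. Among the measured compounds shown here, the one measured step, an at least 19-fold lower number from compound 1 to compound 2 (1.28 log units; beyond the scatter), was large and put trifluoromethyl in place of hydrogen on an aromatic carbon, whereas compound 3 keeps a substituted aromatic ring, so no step beyond the scatter is expected in this assay. The expected change is a 1.2-fold lower number from compound 2 to compound 3 (0.06 log units; within the scatter). For compound 3 the estimated value is 4500 nM, with an expected range of 1500 nM to 14000 nM.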

Compound 3, half-maximal inhibitory concentration: 5500 nM
Compound 3: the middle estimate sits 1.2-fold (0.09 log units) below what was measured, within the range that was stated.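

In this assay, 3,4-dichlorophenyl on the amine nitrogen in the ring matches 4-(trifluoromethyl)phenyl, with a 1.1-fold higher number from compound 2 to compound 3 (0.02 log units; within the scatter). Trifluoromethyl is therefore not required for the gain over unsubstituted phenyl: the series also shows an at least 18-fold lower number from compound 1 to compound 3 (1.25 log units; beyond the scatter). Compound 1 gives a limit and not a number, so both large steps from it have only a floor: the limit of > 100000 nM in this assay, at which 1 of the 3 values shown sits.

Open, going by these compounds, is whether a single chlorine would hold this level on the phenyl ring. Also open, on these data alone, is whether a methoxy group, a nitrile or a carboxylic acid there would do the same.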